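Dichlorophenyl to Difluorophenyl on the Carbonyl Carbon

This account rests on a few compounds, and the source may have more. Where it says the series, first, only, none or still open, it means among the compounds named here.

Measured compounds:
- compound 1, `COc1cc(-c2cc(/C=C/C(=O)c3ccc(Cl)c(Cl)c3)[nH]n2)cc(OC)c1OC`, in a functional assay on NCI-H322M cells (Homo sapiens) for cytotoxicity, read by sulforhodamine B assay, with a stated time of 48 h, tested at 0.1 uM (on this read-out lower numbers stand for a stronger effect and higher numbers for a weaker effect at the one concentration tested), compound 1 gives 92%
- compound 2, `COc1cc(C(=O)/C=C/c2cc(-c3cc(OC)c(OC)c(OC)c3)n[nH]2)cc(OC)c1OC`, in this assay compound 2 gives 97%

Both measured compounds leave most of the cells' growth untouched at the single concentration tested. Compound 1 stands at one end of the two numbers, but its distance to compound 2 is within the usual scatter, so the two cannot be told apart on this read-out.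

Compound 3, `COc1cc(-c2cc(/C=C/C(=O)c3ccc(F)c(F)c3)[nH]n2)cc(OC)c1OC`, is built from compound 1 by one change: 3,4-difluorophenyl in place of 3,4-dichlorophenyl on a carbonyl carbon. For the measured compounds named here, no measured pair shows what this change does in this assay, so nothing in the data points to a direction. The step of a number 1 percentage points higher from compound 1 to compound 3 (within the scatter) is therefore expected to stay within the scatter, with no shift beyond it. On this basis compound 3 is estimated at 93%, in a range from 80% to 105%.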

Compound 3, a percentage reported as activity, at one concentration (the size of the read-out at that concentration, not a potency): 94%
The estimate for compound 3 lay 1 percentage points below the measured number; low and high end bracket the measured number.
By their numbers in this assay, from the lowest: compounds 1, 3 and 2 (each within the scatter of the next).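

For the compounds shown here, this pair gives the first direct reading at this place. In this assay, 3,4-difluorophenyl in place of 3,4-dichlorophenyl on a carbonyl carbon gives a number 2 percentage points higher from compound 1 to compound 3 (within the scatter), so this exchange of one halogen pair for the other cannot be told apart on this read-out. Nothing measured here bears on why the result came out this way.

The compounds shown leave open whether a phenyl ring carrying a carboxylic acid or a dimethylamino group, rather than two halogens, would move the number beyond the scatter at this place. They also leave open whether the two halogen pairs would still match at a concentration where the cells respond more strongly, since a single concentration near the untouched end of the scale shows only the size of the effect at that concentration.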